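The source may report more compounds than this note shows. Statements on the series, on what has been measured and on what is new or still open speak of the compounds shown alone.

Measured so far in an ADME assay on L6 cells (Rattus norvegicus) for cytotoxicity, read by resazurin assay, with a stated time of 72 h; a higher number here means a weaker inhibitor, a lower number a stronger inhibitor:
- compound 1 (`Cc1csc(C(=O)NCCCn2cnc([N+](=O)[O-])n2)c1`) gives 173000 nM
- compound 2 (`O=C(NCCCCn1ccnc1[N+](=O)[O-])c1ccsc1`) is entered as "not determined" (no result reported)
- compound 3 (`Cc1csc(C(=O)NCCCCn2ccnc2[N+](=O)[O-])c1`) is entered as "not determined" (no result reported)

Within the data shown here, compound 1 is the only compound here with a number, so it cannot yet be ranked against anything. Among the measured compounds shown here, no pair of measured compounds shows what a change at any place does in this assay, and the two entries without a result add nothing to this.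

Compound 4 (`O=C(NCCCn1cnc([N+](=O)[O-])n1)c1ccnc(Cl)c1`) keeps the core of compound 1 and awaits measurement. The change (2-chloropyridin-4-yl in place of 4-methylthiophen-2-yl on a carbonyl carbon) puts 2-chloropyridin-4-yl in place of 4-methylthiophen-2-yl on a carbonyl carbon, so one six-membered aromatic ring stands where one five-membered aromatic ring stood.

For the measured compounds named here, with no measured step to lean on, the only anchor is compound 1 at 173000 nM, and any expectation starts from that number. A small shift toward a lower number is expected, one that would not clearly leave the usual scatter of repeated measurements. The expected change is a 1.3-fold lower number from compound 1 to compound 4 (0.12 log units; within the scatter) and it carries wide uncertainty. For compound 4 the estimated value is 130000 nM, with an expected range from 40000 nM to 350000 nM.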

Compound 4, half-maximal inhibitory concentration: > 322000 nM
Compound 4: a limit, no number; the forecaster's own chance of this, stated with the estimate: 20%; middle value at least 2.4-fold (0.39 log units) from the limit.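

In this assay, among these compounds, 2-chloropyridin-4-yl in place of 4-methylthiophen-2-yl on a carbonyl carbon gives the first readable step: an at least 1.8-fold higher number from compound 1 to compound 4 (0.26 log units; that floor lies within the scatter). That floor does not establish a change beyond the scatter, but it does show that this six-membered aromatic ring, with its chlorine, gives no lower number at this place than the five-membered aromatic ring of the core of compound 1. The reading for compound 4 is a limit and not a number: the limit of > 322000 nM in this assay, at which 1 of the 4 values shown sits.

As far as these compounds go, the true size of the step stays open, as does whether any shift belongs to the change of ring or to the chlorine. A plain pyridin-4-yl would separate those two parts, and an amine in place of the chlorine on the same ring would show whether this place responds to anything other than a halogen.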